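A few compounds are considered here, and "the series" means these few. Any claim that something is new, unique, unknown or untested is made for them only; others in the source may bear on it.

Compound 1 (`C=CC(=O)Nc1cc2c(Nc3ccc(OCc4cccc(F)c4)c(Cl)c3)ncnc2cc1OCc1cn(CCCC(=O)NO)nn1`) and compound 2 (`C=CC(=O)Nc1cc2c(Nc3ccc(F)c(Cl)c3)ncnc2cc1OCc1cn(CCC(=O)NO)nn1`) both carry a hydroxycarbamoyl group at the end of a saturated chain, and both have been tested in a functional assay on A549 cells (Homo sapiens) for antiproliferative activity, read by MTT assay, with a stated time of 72 h (a higher number here means a weaker inhibitor, a lower number a stronger inhibitor), so far. Compound 1 gives > 50000 nM as a limit of the assay, not a number. Compound 2 gives > 50000 nM as a limit too, so it has no exact value and stands with the limit of > 50000 nM in this assay, at which 2 of the 2 values shown sit, as its only company. Compound 3 (`C=CC(=O)Nc1cc2c(Nc3ccc(F)c(Cl)c3)ncnc2cc1OCc1cn(CCCC(=O)NO)nn1`) follows from compound 2 by one change, ((hydroxycarbamoyl)methyl in place of hydroxycarbamoyl on a saturated chain carbon, two bonds along the chain from an aromatic nitrogen), which turns 2-(hydroxycarbamoyl)ethyl into 3-(hydroxycarbamoyl)propyl. Among the compounds with values here, no measured pair isolates this change. The expectation in this assay is therefore no step beyond the scatter, and it rests on compound 2 and its limit > 50000 nM alone. The estimate means a number no higher from compound 2 to compound 3 (the limit leaves the size open) as the expected step. Compound 3 is expected at 50000 nM within an estimated range of 15000 nM to 100000 nM and may well return only a limit.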

Compound 3, half-maximal inhibitory concentration: > 50000 nM
Compound 3 ended at the assay's limit; the forecaster's own chance of this, stated with the estimate: 70%; the middle value sits exactly at the limit.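

Compound 1, compound 2 and compound 3 each return only a limit, so no step between compound 3 and either of the others can be read: the limit of > 50000 nM in this assay, at which 3 of the 3 values shown sit.

The compounds shown leave open how far each lies past that limit, and whether either change affects the result at all.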